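The source may report more compounds than this note shows. Statements on the series, on what has been measured and on what is new or still open speak of the compounds shown alone.

In an assay on CHO cells for antagonist activity at transient receptor potential cation channel subfamily V member 1 (Homo sapiens), read by FLIPR (on this read-out lower numbers stand for stronger inhibition and higher numbers for weaker inhibition), compound 3, `CC(C(=O)NCc1ccc(C(F)(F)F)cc1OCc1ccccc1)c1ccc(NS(C)(=O)=O)c(F)c1`, gives 0.9 nM. Compound 1, `CCC1CCN(c2cc(C(F)(F)F)ccc2CNC(=O)C(C)c2ccc(NS(C)(=O)=O)c(F)c2)CC1`, gives 0.7 nM in this assay, and compound 2, `CC(C(=O)NCc1ccc(C(F)(F)F)cc1N1CCC(C(F)(F)F)CC1)c1ccc(NS(C)(=O)=O)c(F)c1`, gives 0.4 nM. Compound 3 thus carries the highest of the three numbers: the gap a 1.3-fold higher number from compound 1 to compound 3 (0.11 log units; within the scatter) lies within the scatter, whereas a 2.3-fold higher number from compound 2 to compound 3 (0.35 log units; beyond the scatter) is a modest step beyond it. Compound 4, `CC(C(=O)NCc1ccc(C(F)(F)F)cc1SCc1ccco1)c1ccc(NS(C)(=O)=O)c(F)c1`, differs from compound 3 at one place: ((furan-2-yl)methyl)sulfanyl in place of benzyloxy on an aromatic carbon. The two measured steps that touch this aromatic carbon, a 1.3-fold higher number from compound 1 to compound 3 (0.11 log units; within the scatter) and a 2.3-fold higher number from compound 2 to compound 3 (0.35 log units; beyond the scatter), each exchanged a piperidinyl group for benzyloxy and moved the number only a little, while a 1.8-fold lower number from compound 1 to compound 2 (0.24 log units; within the scatter) on the saturated ring stayed within the scatter. Going by the values given here, no measured step exchanges benzyloxy for ((furan-2-yl)methyl)sulfanyl, so the expectation rests on the apparent tolerance of this position to quite different groups. Compound 4 is therefore expected to give about 1.5 nM, within 0.5 nM to 5 nM, an estimated step of a 1.7-fold higher number from compound 3 to compound 4 (0.22 log units; within the scatter) that need not exceed the scatter.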

Compound 4, inhibition constant: 3.2 nM
The estimate for compound 4 lay 2.1-fold (0.33 log units) below the measured number; low and high end bracket the measured number.
By their numbers in this assay, from the lowest: compounds 2, 1 and 3 (each within the scatter of the next, the first and the last beyond it); then compound 4.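

In this assay, going by these compounds alone, the exchange of benzyloxy for ((furan-2-yl)methyl)sulfanyl gives a 3.6-fold higher number from compound 3 to compound 4 (0.55 log units; beyond the scatter) and so shows that this aromatic carbon is less forgiving than the earlier compounds suggested, since their largest step here was smaller. Measured against the piperidine-bearing compounds, the change gives a 4.6-fold higher number from compound 1 to compound 4 (0.66 log units; beyond the scatter) and an 8.0-fold higher number from compound 2 to compound 4 (0.90 log units; beyond the scatter) and leaves compound 4 beyond the scatter of all three others, with the highest number of the four. Nothing available here accounts for this loss.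

The step changes the linking oxygen to sulfur and the benzene ring to furan at once, so the compounds shown do not tell which of the two changes carries it. A benzylsulfanyl or a (furan-2-yl)methoxy group at this position would separate them.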